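The compounds below may be only part of what the source reports. "The series", "measured", "known", "first", "only" and "open" are said of these compounds alone.

Values in an ADME assay on MRC5 cells (Homo sapiens) for cytotoxicity, read by MTT assay, with a stated time of 72 h; a higher number here means a weaker inhibitor, a lower number a stronger inhibitor:

- compound 1 `Cc1ccc(C(=O)Nc2nnc(-c3ccc(O)c(O)c3)s2)cc1` gives 27100 nM
- compound 2 `O=C(Nc1nnc(-c2ccc(O)c(O)c2)s1)C1CCCCC1` gives 24000 nM
- compound 3 `O=C(Nc1nnc(-c2ccc(O)c(O)c2)s1)c1ccc(Cl)cc1` is not yet measured

Within the data shown here, compound 2 stands within the scatter of compound 1 in this assay, so the two numbers set no order between these compounds. The next change puts 4-chlorophenyl in place of cyclohexyl on a carbonyl carbon whose other neighbours are an amide-type nitrogen (4-chlorophenyl in place of cyclohexyl on a carbonyl carbon). Among the measured compounds shown here, only one measured step bears on this place. That step, a 1.1-fold lower number from compound 1 to compound 2 (0.05 log units; within the scatter), exchanged cyclohexyl for 4-methylphenyl on the same carbonyl carbon and stayed within the scatter. For the measured compounds named here, it is a single step, and no measured compound yet carries 4-chlorophenyl, so the evidence for the new group is indirect. With an aromatic ring at this place, compound 1 still gives 27100 nM, so no shift beyond the scatter is expected here. The expected result is a 1.0-fold higher number from compound 2 to compound 3 (0.02 log units; within the scatter), which is no real change. Compound 3 is estimated at 25000 nM, with an expected range of 12000 nM to 50000 nM.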

Compound 3, half-maximal inhibitory concentration: 30600 nM
Beside the measured number, compound 3's estimate is 1.2-fold (0.09 log units) below it; measured number inside the range.
By their numbers in this assay, from the lowest: compounds 2, 1 and 3 (each within the scatter of the next).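

Notes on the carbonyl carbon: in this assay, 4-chlorophenyl in place of cyclohexyl gives a 1.3-fold higher number from compound 2 to compound 3 (0.11 log units; within the scatter) and so adds a second aromatic group that does not separate from the non-aromatic cyclohexyl. Chloro in place of methyl on an aromatic carbon gives a 1.1-fold higher number from compound 1 to compound 3 (0.05 log units; within the scatter), the first comparison in the series of two substituents on the same aromatic ring, and it too sets no order. All three groups at this place, 4-methylphenyl, cyclohexyl and 4-chlorophenyl, therefore lie within the scatter of one another, and nothing available gives a reason for this absence of separation.

The compounds shown leave open whether a group of a different kind at this place, such as an amine or a carboxylic acid on the aromatic ring, or a longer carbon chain in place of the ring, would produce a step beyond the scatter. As far as these compounds go, all three compounds also share the same core, so what a change to the core would do to the number in this assay remains open.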